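Trimethoxybenzyl Purine Series: Chain Swap at the Ring Nitrogen

The compounds below may be only part of what the source reports. "The series", "measured", "known", "first", "only" and "open" are said of these compounds alone.

Compound 1 `COc1cc(Cc2nc3c(N)ncnc3n2CC2CCCO2)cc(OC)c1OC` gives 91200 nM in a functional assay on MCF7 cells (Homo sapiens) for antiproliferative activity (on this read-out lower numbers stand for stronger inhibition and higher numbers for weaker inhibition), the highest of the three numbers in hand. Compound 2 `CCCCCn1c(Cc2cc(OC)c(OC)c(OC)c2)nc2c(N)nc(F)nc21` gives 36300 nM, and compound 3 `COc1cc(Cc2nc3c(N)nc(F)nc3n2CC2CCCO2)cc(OC)c1OC` gives 22900 nM; the gain from compound 1 to compound 3 is a 4.0-fold lower number from compound 1 to compound 3 (0.60 log units; beyond the scatter). Compound 4 `C=CCCn1c(Cc2cc(OC)c(OC)c(OC)c2)nc2c(N)ncnc21` differs from compound 1 by allyl in place of oxolan-2-yl on a saturated chain carbon bound to an aromatic nitrogen. Going by the values given here, the only measured step touching the same position is a 1.6-fold lower number from compound 2 to compound 3 (0.20 log units; within the scatter), which stays within the scatter, so exchanging the chain on the saturated carbon bound to the aromatic nitrogen has so far left this read-out essentially unchanged. No step beyond the scatter is therefore expected here either; the change from compound 1 to compound 4 is estimated at a 1.3-fold higher number from compound 1 to compound 4 (0.12 log units; within the scatter). For compound 4 the expected value is 120000 nM, within a range of 50000 nM to 300000 nM.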

Compound 4, half-maximal inhibitory concentration: 40700 nM
Estimate against measurement, compound 4: 2.9-fold (0.47 log units) above; the measured number lies below the stated range.
By their numbers in this assay, from the lowest: compounds 3, 2 and 4 (each within the scatter of the next); then compound 1.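

In this assay, allyl in place of oxolan-2-yl on a saturated chain carbon bound to an aromatic nitrogen gives a 2.2-fold lower number from compound 1 to compound 4 (0.35 log units; beyond the scatter), so a chain exchange at this position can move the number beyond the scatter. The earlier chain exchange on the fluoro compounds, a 1.6-fold lower number from compound 2 to compound 3 (0.20 log units; within the scatter), did not show this. No evidence in hand gives a cause for the step.

Still open, as far as these compounds go, is whether fluoro on compound 4 would lower the number further. From the compounds shown here alone, a longer chain or a terminal amine at this position also remains untested here.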